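Removing Both Chlorines from the Amide Aryl Group

A few compounds are considered here, and "the series" means these few. Any claim that something is new, unique, unknown or untested is made for them only; others in the source may bear on it.

Compound 1 `O=C(COc1ccc2cc(/C=C3/SC(=O)NC3=O)ccc2c1)Nc1c(F)cc(F)cc1Br`: 1100 nM
Compound 2 `Cc1cc(Br)ccc1NC(=O)COc1ccc2cc(/C=C3/SC(=O)NC3=O)ccc2c1`: 550 nM
Compound 3 `O=C(COc1ccc2cc(/C=C3/SC(=O)NC3=O)ccc2c1)Nc1ccc(Cl)c(Cl)c1`: 5500 nM

These three compounds share one core and differ only in the aryl group on the amide-type nitrogen. In an assay on isolated protein for inhibition of histone deacetylase 4 (Homo sapiens), with a stated time of 1 h (a lower number here means a stronger inhibitor, a higher number a weaker inhibitor), compound 3 gives the highest number of the three: a 5.0-fold higher number from compound 1 to compound 3 (0.70 log units; beyond the scatter) and a 10-fold higher number from compound 2 to compound 3 (1.00 log units; beyond the scatter), while a 2.0-fold lower number from compound 1 to compound 2 (0.30 log units; within the scatter). Compound 4 `O=C(COc1ccc2cc(/C=C3/SC(=O)NC3=O)ccc2c1)Nc1ccccc1` has not been measured; it differs from compound 3 by phenyl in place of 3,4-dichlorophenyl on an amide-type nitrogen. For the measured compounds named here, the two steps that end at compound 3 show that swapping one substituted aryl group for another can shift the number markedly, but neither step strips the ring bare, so no measured step directly matches this change. The expected step is a 1.1-fold lower number from compound 3 to compound 4 (0.04 log units; within the scatter), within the scatter. Compound 4 is therefore estimated at 5000 nM, with a range from 1500 nM to 16000 nM.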

Compound 4, half-maximal inhibitory concentration: 2100 nM
Compound 4: the middle estimate sits 2.4-fold (0.38 log units) above what was measured; the range from low to high includes it.
By their numbers in this assay, from the lowest: compounds 2, 1 and 4 (each within the scatter of the next, the first and the last beyond it); then compound 3.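

In this assay, the phenyl compound shows this position with no substituent on the ring: losing both chlorines gives a 2.6-fold lower number from compound 3 to compound 4 (0.42 log units; beyond the scatter) and so 3,4-dichlorophenyl brings no gain over bare phenyl. Against 4-bromo-2-methylphenyl, bare phenyl falls behind with a 3.8-fold higher number from compound 2 to compound 4 (0.58 log units; beyond the scatter) and so substituents here can also improve on it. Against 2-bromo-4,6-difluorophenyl there is a 1.9-fold higher number from compound 1 to compound 4 (0.28 log units; within the scatter) and so no real difference.

Nothing available explains these shifts. Still open, going by these compounds, is how an amine or a carboxylic acid on this ring would compare.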